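This account rests on a few compounds, and the source may have more. Where it says the series, first, only, none or still open, it means among the compounds named here.

Measured in a physicochemical assay for lipophilicity, measured as chromatographic lipophilicity, at pH 7.4; on this read-out higher numbers stand for higher lipophilicity and lower numbers for lower lipophilicity:
- Compound 1 (`COc1cc(-c2nnc3n2CCCC3c2ccc(Cl)c(Cl)c2)ccc1-c1cnc(C)o1`): 3.2
- Compound 2 (`COc1cc(-c2nnc3n2CCCC3(O)c2ccc(Cl)c(Cl)c2)ccc1-c1cnc(C)o1`): 2.9
- Compound 3 (`COc1cc(-c2nnc3n2CCCC3(c2ccc(F)c(F)c2)C(C)(C)O)ccc1-c1cnc(C)o1`): 2.9

Compound 3 stands level with compound 2, and compound 1 lies within the scatter of both. Compound 4 (`COc1cc(-c2nnc3n2CCCC3(Oc2cc(F)c(F)c(F)c2)C(C)(C)O)ccc1-c1cnc(C)o1`) carries 3,4,5-trifluorophenoxy in place of 3,4-difluorophenyl on a saturated ring carbon. For the measured compounds named here, the only measured step, a number 0.30 log units lower from compound 1 to compound 2 (within the scatter), stays within the scatter, but it is hydroxy in place of hydrogen, a different exchange, so it bears only weakly. Going by the values given here, no measured step covers the new group, so the expectation is loose. A small upward step is expected in this assay: a number 0.40 log units higher from compound 3 to compound 4 (beyond the scatter). For compound 4 the estimate is 3.3, with an expected range from 2.8 to 3.8.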

Compound 4, distribution coefficient: 3.2
Compound 4: the middle estimate sits 0.10 log units above what was measured, within the range that was stated.
By their numbers in this assay, from the lowest: compounds 2, 3, 1 and 4 (each within the scatter of the next).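

At this saturated ring carbon, two ring bonds from the ring nitrogen, the earlier compounds had not shown an exchange of the aromatic group itself. Here 3,4,5-trifluorophenoxy, with 10 heavy atoms and 1 hydrogen-bond acceptor, takes the place of 3,4-difluorophenyl, with 8 heavy atoms and 0 hydrogen-bond acceptors, and gives a number 0.30 log units higher from compound 3 to compound 4 (within the scatter) in this assay. No measured evidence accounts for this step.

The compounds shown do not separate the oxygen link from the third fluorine. From the compounds shown here alone, how an amine on this carbon would read in this assay remains open.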